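Swapping bromine for chlorine on a flavone ester side chain

The source may hold more compounds than are shown below. What is called first, only, known or untested is meant among the compounds shown, and "the series" means these compounds.

Measured so far:
compound 1 `COC(=O)c1cccc(OC)c1OC(=O)COc1cc(O)c2c(=O)cc(-c3ccccc3)oc2c1` gives 36800 nM
compound 2 `COC(=O)c1c(Br)cccc1OC(=O)COc1cc(O)c2c(=O)cc(-c3ccccc3)oc2c1` gives 41700 nM

Both compounds share the same core and were tested in a functional assay on cells (T-cell, Mus musculus, strain BALB/c) for inhibition, read by MTT assay, with a stated time of 72 h; a lower number here means a stronger inhibitor, a higher number a weaker inhibitor. Compound 2 shows the higher of the two numbers, but its gap to compound 1 is within the scatter, so the two compounds cannot be told apart on these data.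

Compound 3 `COC(=O)c1cccc(Cl)c1OC(=O)COc1cc(O)c2c(=O)cc(-c3ccccc3)oc2c1` has not yet been measured. It differs from compound 2 in one place: a group of 11 heavy atoms (8 carbon, 2 oxygen, 1 chlorine; one six-membered aromatic ring of carbon only) in place of a group of 11 heavy atoms (8 carbon, 2 oxygen, 1 bromine; one six-membered aromatic ring of carbon only), on an oxygen next to a carbonyl group. In plain terms, the bromine-bearing group on the oxygen next to the carbonyl is replaced by the 2-chloro-6-(methoxycarbonyl)phenyl group, so one halogen gives way to another.

Going by the values given here, no step between two measured compounds is available to guide this change, and the halogen exchange is a small one. The step from compound 2 to compound 3 is therefore expected to be a 1.1-fold lower number from compound 2 to compound 3 (0.04 log units; within the scatter), that is, nothing beyond the scatter in either direction. Compound 3 is accordingly expected to give about 38000 nM in this assay, with a likely range from 15000 nM to 95000 nM.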

Compound 3, half-maximal inhibitory concentration: 38700 nM
Compound 3: the middle estimate sits 1.0-fold (0.01 log units) below what was measured; low and high end bracket the measured number.
By their numbers in this assay, from the lowest: compounds 1, 3 and 2 (each within the scatter of the next).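

In this assay, the 2-chloro-6-(methoxycarbonyl)phenyl group in place of the bromine-bearing group, on an oxygen next to a carbonyl group, gives a 1.1-fold lower number from compound 2 to compound 3 (0.03 log units; within the scatter), while chloro in place of methoxy on an aromatic carbon gives a 1.1-fold higher number from compound 1 to compound 3 (0.02 log units; within the scatter). Going by these compounds alone, these are the first steps that can be read between compounds differing in one place, and neither goes beyond the scatter, so within this small set, neither exchanging the halogen-bearing group nor exchanging chloro for methoxy produces a difference that these data can resolve. Nothing available explains why these numbers lie so close together.

Three closely related compounds cannot show whether this part of the molecule is generally tolerant of change, since the groups compared here are limited to chloro, methoxy and a bromine-bearing group. From the compounds shown here alone, it remains open whether an amine on the aromatic ring, a carboxylic acid in place of the methyl ester, or a longer chain on the oxygen next to the carbonyl group would move the number beyond the scatter in either direction.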